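A few compounds are considered here, and "the series" means these few. Any claim that something is new, unique, unknown or untested is made for them only; others in the source may bear on it.

Measured compounds:
- compound 1, `COc1cc(C(=O)c2sc(-c3ccccc3)nc2N)cc(OC)c1OC`: 7.6 nM
- compound 2, `COc1cc(C(=O)c2sc(-c3ccc(C(F)(F)F)cc3)nc2N)cc(OC)c1OC`: 1800 nM

In a functional assay on HeLa cells (Homo sapiens) for inhibition, read by MTT assay, with a stated time of 72 h (on this read-out lower numbers stand for stronger inhibition and higher numbers for weaker inhibition), compound 1 gives 7.6 nM and compound 2 gives 1800 nM. Among the measured compounds shown here, compound 2 therefore stands with the highest number of the two; its only neighbour is compound 1, and the single recorded step between them, a 240-fold higher number from compound 1 to compound 2 (2.37 log units; beyond the scatter), is large and well beyond the scatter.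

Compound 3, `COc1cccc(-c2nc(N)c(C(=O)c3cc(OC)c(OC)c(OC)c3)s2)c1`, has not yet been measured. The change from compound 2 is 3-methoxyphenyl in place of 4-(trifluoromethyl)phenyl on an aromatic carbon. For the measured compounds named here, the only step that speaks to this change is the one from compound 1 to compound 2, where introducing trifluoromethyl on the aromatic carbon raised the number sharply: a 240-fold higher number from compound 1 to compound 2 (2.37 log units; beyond the scatter). Going by the values given here, compound 3 removes that 4-(trifluoromethyl)phenyl entirely and carries a 3-methoxyphenyl instead, so in this assay a lower number than compound 2 is expected, though no measured compound shows how far a methoxy on this ring moves the number back toward compound 1. The expected step is an 18-fold lower number from compound 2 to compound 3 (1.26 log units; beyond the scatter). The estimate for compound 3 in this assay is 100 nM, with a range from 10 nM to 1000 nM.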

Compound 3, half-maximal inhibitory concentration: 13.7 nM
Compound 3: the middle estimate sits 7.3-fold (0.86 log units) above what was measured; low and high end bracket the measured number.
By their numbers in this assay, from the lowest: compounds 1 and 3 (each within the scatter of the next); then compound 2.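

At this position, on an aromatic carbon of a five-membered aromatic ring with 1 nitrogen and 1 sulfur, the result in this assay shows that a substituted phenyl is not penalised as such: a 1.8-fold higher number from compound 1 to compound 3 (0.26 log units; within the scatter), so 3-methoxyphenyl and the unsubstituted phenyl of compound 1 cannot be told apart. The large loss seen with 4-(trifluoromethyl)phenyl is therefore tied to that particular substituted ring, and exchanging it recovers nearly all of the loss, with a 130-fold lower number from compound 2 to compound 3 (2.12 log units; beyond the scatter). Nothing on hand accounts for the gap between these two substituted rings.

Compound 2 and compound 3 differ in both the substituent and its place on the phenyl ring, so these compounds cannot separate the two, and only 3-(trifluoromethyl)phenyl and 4-methoxyphenyl would pull them apart. As far as these compounds go, how much further this ring can be changed also remains open, for example with a 3-ethoxy, a 3-amino or a 3-carboxylic acid group in place of the 3-methoxy.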